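The source may report more compounds than this note shows. Statements on the series, on what has been measured and on what is new or still open speak of the compounds shown alone.

Compound 1 `O=C(Nc1cccc(-n2cc(-c3ccncc3)c(-c3cc(O)cc(Cl)c3)n2)c1)Nc1ccc(Cl)c(C(F)(F)F)c1` and compound 2 `COc1cc(Cl)cc(-c2nn(-c3cccc(NC(=O)Nc4ccc(Cl)c(C(F)(F)F)c4)c3)cc2-c2ccncc2)c1` share one core and differ at a single oxygen on an aromatic ring, where compound 2 carries methyl in place of hydrogen. In a functional assay on LOX IMVI cells (Homo sapiens) for inhibition, read by sulforhodamine B assay, with a stated time of 48 h, tested at 1 uM (a higher number here means a weaker effect of the compound at the concentration tested, a lower number a stronger effect), compound 1 gives 93%, while compound 2 gives 61%; that one change produced a number 32 percentage points lower from compound 1 to compound 2 (beyond the scatter). Of the two measured compounds, compound 2 therefore has the lowest number, meaning the stronger effect at the tested concentration.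

Compound 3 `COc1cc(Cl)cc(-c2nn(-c3cccc(NC(=O)Nc4cccc(C(F)(F)F)c4)c3)cc2-c2ccncc2)c1` is compound 2 with hydrogen in place of chloro on an aromatic carbon, placed on the aromatic carbon ortho to a trifluoromethyl group. Within the data shown here, no measured step touches that part of the molecule; the only known step, methyl for hydrogen on oxygen, says nothing about removing a chloro there. A modest weakening is expected, a number 11 percentage points higher from compound 2 to compound 3 (beyond the scatter), near the edge of the scatter. Compound 3 is thus estimated at 72% in this assay, with a range from 50% to 95%.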

Compound 3, a percentage reported as activity, at one concentration (the size of the read-out at that concentration, not a potency): 72%
Compound 3: middle estimate and measured number agree at the digits printed; measured number inside the range.
By their numbers in this assay, from the lowest: compound 2; then compound 3; then compound 1.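

Taking away the chloro, so that 4-chloro-3-(trifluoromethyl)phenyl becomes 3-(trifluoromethyl)phenyl, gives a number 11 percentage points higher from compound 2 to compound 3 (beyond the scatter) in this assay and so a weaker effect at the tested concentration. This shows that the chloro, ortho to a trifluoromethyl group, contributes to the effect of compound 2, making this a second place in the molecule, after the oxygen on the other aromatic ring, where a single change moves the number beyond the scatter. Nothing available explains this shift.

Still open, on these data alone, is whether another group at this place, such as a fluoro, a methyl or an amine, would match the chloro. As far as these compounds go, it is also open whether the chloro would count for as much with the hydroxyl of compound 1 in place of the methoxy of compound 2.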